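A few compounds are considered here, and "the series" means these few. Any claim that something is new, unique, unknown or untested is made for them only; others in the source may bear on it.

Working notes on the series. Compound 1 `CCCS(=O)(=O)Nc1ccc(F)c(C(=O)c2n[nH]c3ncc(-c4ccccc4OC)cc23)c1F` and compound 2 `CCCS(=O)(=O)Nc1ccc(F)c(C(=O)c2n[nH]c3ncc(-c4cccc(OC)c4)cc23)c1F` share one core and differ only in where the methoxy sits on the pendant ring. In an assay for binding affinity to dual specificity mitogen-activated protein kinase kinase 4 (Homo sapiens), read by KINOMEscan, tested at 100 nM (a lower number here means a stronger effect, a higher number a weaker effect of the compound at the concentration tested), compound 1 gives 1.9%. In this assay compound 2 gives 6.3%. Within the data shown here, compound 2 is one of only two numbers so far, the other belonging to compound 1, and the step of a number 4.4 percentage points higher from compound 1 to compound 2 (within the scatter) is within the scatter, so the two stand together.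

Compound 3 `CCCS(=O)(=O)Nc1ccc(F)c(C(=O)c2n[nH]c3ncc(-c4cccc(C(F)(F)F)c4)cc23)c1F` is not yet measured. It differs from compound 2 as follows: trifluoromethyl in place of methoxy on an aromatic carbon. Among the measured compounds shown here, no measured step exchanges methoxy for trifluoromethyl; the single step of a number 4.4 percentage points higher from compound 1 to compound 2 (within the scatter) concerns the position of the methoxy and does not bear directly on this exchange. It does show that the pendant ring tolerates a change of group without the number leaving the scatter.

For compound 3 the expectation is therefore a step of a number 3.7 percentage points higher from compound 2 to compound 3 (within the scatter) in this assay that is most likely not beyond the scatter, with some room for a weaker effect. Compound 3 is estimated at 10% in this assay, within 2% to 35%.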

Compound 3, a percentage reported as activity, at one concentration (the size of the read-out at that concentration, not a potency): 57%
Estimate against measurement, compound 3: 47 percentage points below, outside the stated range (above it).
By their numbers in this assay, from the lowest: compounds 1 and 2 (each within the scatter of the next); then compound 3.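

In this assay, the group on this aromatic carbon matters far more than the position of the methoxy suggested: trifluoromethyl in place of methoxy gives a number 50.7 percentage points higher from compound 2 to compound 3 (beyond the scatter). The change to 3-(trifluoromethyl)phenyl from 2-methoxyphenyl points the same way, with a number 55.1 percentage points higher from compound 1 to compound 3 (beyond the scatter), whereas the step between the two methoxy isomers stayed within the scatter. The pendant ring therefore tolerates a shift of the methoxy but not this exchange of methoxy for trifluoromethyl, and nothing available here bears on why the number changes so much.

The compounds shown leave open whether the large step follows from the arrival of trifluoromethyl or from the departure of methoxy, and a methyl, a chlorine or a hydroxy group on the same carbon would help to separate the two. As far as these compounds go, it is also open whether trifluoromethyl on the ring position that carries the methoxy in compound 1 would give a similar number, or whether a longer ether such as ethoxy would stay with the two methoxy compounds.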